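Adding a methyl to compound 2

The source may report more compounds than this note shows. Statements on the series, on what has been measured and on what is new or still open speak of the compounds shown alone.

In a functional assay on the whole organism for agonist activity, with Mus musculus as the target (on this read-out higher numbers stand for an effect only at larger amounts of compound and lower numbers for an effect already at smaller amounts), compound 1 `COC(=O)N(C)CC#CCn1cncc1C` gives > 100 mg/kg as a limit of the assay. Compound 2 `Cc1cncn1CC#CCN1CCNC1=O` gives > 100 mg/kg as a limit too, not a number. Both stand at the limit of > 100 mg/kg in this assay, at which 2 of the 2 values shown sit, and no measured number is yet in hand. Compound 3 `Cc1cncn1CC#CCN1CCN(C)C1=O` has methyl in place of hydrogen on an amide-type nitrogen in a ring. Among the measured compounds shown here, no measured step bears on this change, so the expected a number no higher from compound 2 to compound 3 (the limit leaves the size open) in this assay is none beyond the scatter, in neither direction. The estimate for compound 3 is 100 mg/kg with an expected range from 40 mg/kg to 250 mg/kg here.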

Compound 3, dose for half-maximal effect: > 100 mg/kg
Compound 3 gave a limit, no number (the forecaster's own chance of this, stated with the estimate: 75%); the middle value lies on the limit itself.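

No step can be read from compound 2 to compound 3, since both values are limits and not numbers: the limit of > 100 mg/kg in this assay, at which 3 of the 3 values shown sit.

The compounds shown leave open whether methyl in place of hydrogen on an amide-type nitrogen in a ring changes the read-out in this assay at all.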